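A few compounds are considered here, and "the series" means these few. Any claim that something is new, unique, unknown or untested is made for them only; others in the source may bear on it.

Measured compounds:
compound 1 `COc1cc(N(CC2CC2)c2ccc(Cl)c(Cl)c2)cnc1C(=O)[C@H]1C[C@@H]1C(=O)O` with 27.7 nM
compound 2 `COc1cc(N(CC(C)C)c2ccc(F)c3ccccc23)cnc1C(=O)[C@H]1C[C@@H]1C(=O)O` with 2.26 nM
compound 3 `CCN(c1cnc(C(=O)[C@H]2C[C@@H]2C(=O)O)c(OC)c1)c1ccc(F)c2ccccc12` with 16.8 nM

In an assay on isolated protein for inhibition of leukotriene C4 synthase (Homo sapiens), read by LC-MS, with stated times of 45 min and 20 min (on this read-out lower numbers stand for stronger inhibition and higher numbers for weaker inhibition), compound 1 gives the highest of the three numbers. Compound 3 lies within the scatter of compound 1, so the two cannot be ordered; compound 2 is beyond the scatter and gives the lower number of the pair.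

Compound 4 `COc1cc(N(CC2CC2)c2cccc(C(F)(F)F)c2)cnc1C(=O)[C@H]1C[C@@H]1C(=O)O` has not been measured. It differs from compound 1 in one place: 3-(trifluoromethyl)phenyl in place of 3,4-dichlorophenyl on a nitrogen on an aromatic ring. Among the measured compounds shown here, the only step measured here, a 7.4-fold higher number from compound 2 to compound 3 (0.87 log units; beyond the scatter), concerns the saturated chain on the nitrogen, not the aromatic group attached to it, so no measured step speaks directly to the change from compound 1 to compound 4. With nothing to indicate a direction, the expectation is that compound 4 stays near compound 1, with any step a 1.1-fold higher number from compound 1 to compound 4 (0.03 log units; within the scatter) not clearly beyond the scatter. Compound 4 is therefore estimated at 30 nM in this assay, with a range from 8 nM to 110 nM.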

Compound 4, half-maximal inhibitory concentration: 52.4 nM
Compound 4: middle estimate off by 1.7-fold (0.24 log units), on the low side; the range from low to high includes it.
By their numbers in this assay, from the lowest: compound 2; then compounds 3, 1 and 4 (each within the scatter of the next, the first and the last beyond it).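

In this assay, 3-(trifluoromethyl)phenyl in place of 3,4-dichlorophenyl gives a 1.9-fold higher number from compound 1 to compound 4 (0.28 log units; within the scatter), so the two groups cannot be ordered at this position. Among the compounds shown here, this is the first measured step in the aromatic group on the nitrogen, as the earlier step concerned only the saturated chain, and here a group of 10 heavy atoms replaces one of 8 with the chain on the nitrogen unchanged and no step beyond the scatter. Nothing available gives a reason for this result.

The compounds shown leave open whether an aromatic ring carrying an amine, a nitrile or a carboxylic acid would also stay within the scatter of compound 1. They also leave open whether this same exchange of aromatic groups would read alike with a longer chain on the nitrogen.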